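This account rests on a few compounds, and the source may have more. Where it says the series, first, only, none or still open, it means among the compounds named here.

Measured so far in an assay on membranes from brain (strain Sprague-Dawley) for displacement of a labelled ligand from metabotropic glutamate receptor 5 (Rattus norvegicus), read by scintillation counting, with a stated time of 60 min; on this read-out lower numbers stand for stronger inhibition and higher numbers for weaker inhibition:
compound 1 `N#Cc1cccc(C#Cc2cccc(C#N)n2)c1` gives 8.2 nM
compound 2 `N#Cc1cccc(C#Cc2cccc(F)n2)c1` gives 150 nM

Compound 2 stands at the highest of the two numbers in this assay; its nearest neighbour is compound 1, and the step of an 18-fold higher number from compound 1 to compound 2 (1.26 log units; beyond the scatter) is a large one, well beyond the scatter.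

Compound 3 `CC(=O)c1cccc(C#Cc2cccc(C#N)c2)n1` differs from compound 2 in one place: acetyl in place of fluoro on an aromatic carbon. Among the measured compounds shown here, no measured step involves an acetyl group, so the only guide is the one step that is known, an 18-fold higher number from compound 1 to compound 2 (1.26 log units; beyond the scatter), which shows that the fluoro-bearing compound 2 sits far above the cyano-bearing compound 1. Leaving the fluoro behind is the shared feature of the known step and the one now being followed; what the acetyl does in its place is untested here, so the expectation carries wide error.

On that basis the number for compound 3 in this assay is expected to fall, giving an estimated step of a 5.0-fold lower number from compound 2 to compound 3 (0.70 log units; beyond the scatter). The estimate for compound 3 is 30 nM, with a range from 8 nM to 120 nM.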

Compound 3, inhibition constant: 114 nM
Beside the measured number, compound 3's estimate is 3.8-fold (0.58 log units) below it; measured number inside the range.
By their numbers in this assay, from the lowest: compound 1; then compounds 3 and 2 (each within the scatter of the next).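

Acetyl and fluoro on this aromatic carbon next to the ring nitrogen cannot be told apart in this assay, as a 1.3-fold lower number from compound 2 to compound 3 (0.12 log units; within the scatter) shows, so the heavier acetyl and the hydrogen-bond acceptor it brings leave the read-out within the scatter of compound 2. Against the cyano of compound 1 the new group gives a 14-fold higher number from compound 1 to compound 3 (1.14 log units; beyond the scatter), a large step that matches fluoro in kind: an 18-fold higher number from compound 1 to compound 2 (1.26 log units; beyond the scatter) is also large and also beyond the scatter. With two quite different replacements now on record, the low number at this position belongs to the cyano group alone among the three groups tried, and the loss on leaving cyano is no longer tied to fluoro in particular.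

Still open, going by these compounds, is whether any other group on this carbon, such as an amine, a methoxy group, a primary amide or a longer chain like propanoyl, can come back to the level of compound 1 on the shared core. Nothing measured here explains why cyano stands apart from acetyl and fluoro at this position.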